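Cyclopentyl on an Amide-Type Nitrogen in Compound 4

The source may report more compounds than this note shows. Statements on the series, on what has been measured and on what is new or still open speak of the compounds shown alone.

compound 1 `Nc1c(C(=O)N/N=C/c2ccccc2)oc2nc(-c3ccccc3)cc(C(F)(F)F)c12` gives 13100 nM
compound 2 `Nc1c(C(=O)N/N=C/c2ccccc2)oc2nc(-c3cccs3)cc(C(F)(F)F)c12` gives 9900 nM
compound 3 `Cc1ccc(/C=N/NC(=O)c2oc3nc(-c4ccccc4)cc(C(F)(F)F)c3c2N)cc1` gives 8900 nM

In a functional assay on HepG2 cells (Homo sapiens) for antiproliferative activity, read by MTT assay (on this read-out lower numbers stand for stronger inhibition and higher numbers for weaker inhibition), compound 2 gives 9900 nM, a number within the scatter of both compound 1 and compound 3, so it holds no distinct place among the three. The next compound is compound 4 `Nc1c(C(=O)NC2CCCC2)oc2nc(-c3cccs3)cc(C(F)(F)F)c12`, which is not yet measured. The change from compound 2 is a group of 5 heavy atoms (5 carbon; one five-membered non-aromatic ring of carbon only) in place of a group of 8 heavy atoms (7 carbon, 1 nitrogen; one six-membered aromatic ring of carbon only), on an amide-type nitrogen.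

Two measured steps are available. The step of a 1.3-fold lower number from compound 1 to compound 2 (0.12 log units; within the scatter) came with thiophen-2-yl in place of phenyl on an aromatic carbon. The step of a 1.5-fold lower number from compound 1 to compound 3 (0.17 log units; within the scatter) came with methyl in place of hydrogen on an aromatic carbon. Within the data shown here, both lie within the scatter, and neither removes the group that leaves here, so no measured step covers a replacement of this size. The expected move is a 1.4-fold higher number from compound 2 to compound 4 (0.15 log units; within the scatter), with no clear step beyond the scatter, and this expectation is held loosely. For compound 4 the estimated value is 14000 nM, with an expected range from 4000 nM to 50000 nM.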

Compound 4, half-maximal inhibitory concentration: 20800 nM
Compound 4: the middle estimate sits 1.5-fold (0.17 log units) below what was measured; low and high end bracket the measured number.
By their numbers in this assay, from the lowest: compounds 3, 2, 1 and 4 (each within the scatter of the next, the first and the last beyond it).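

In this assay, among these compounds, the amide-type nitrogen is the first place where a change gives a step beyond the scatter: a 2.1-fold higher number from compound 2 to compound 4 (0.32 log units; beyond the scatter), though it is modest, while the two earlier changes on aromatic carbons stayed within the scatter. The step also shows that this nitrogen does not need the leaving group of 8 heavy atoms for a number to be read, as compound 4 with cyclopentyl still gives 20800 nM. No measurement here accounts for the step.

The swap removes the six-membered aromatic ring and the double bond and also shortens the group, and the compounds shown do not separate these changes. Going by these compounds, how benzyl, cyclohexyl or a longer chain such as n-hexyl would read on this nitrogen, or how cyclopentyl would read with phenyl in place of thiophen-2-yl, remains open.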